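Moving the Nitrile from Compound 3 to Compound 4

The source may hold more compounds than are shown below. What is called first, only, known or untested is meant among the compounds shown, and "the series" means these compounds.

Compound 1 `C=CCc1cc(O)c(O)c(CN2CCC(C)CC2)c1`: 41.7%
Compound 2 `C=CCc1cc(O)c(O)c(CN2CCC(CCO)CC2)c1`: 21.4%
Compound 3 `C=CCc1ccc(OCc2cn(-c3ccc(C#N)cc3)nn2)c(O)c1`: 35.7%

These three numbers are all that is known so far. In a functional assay on MCF7 cells (Homo sapiens) for inhibition, read by MTT assay, with a stated time of 72 h, tested at 30 uM (a higher number here means more inhibition of growth at the concentration tested, a lower number less inhibition of growth), compound 3 gives 35.7%, which lies within the scatter of compound 1 and beyond the scatter above compound 2. The next compound to be tested is compound 4 `C=CCc1ccc(OCc2cn(-c3cccc(C#N)c3)nn2)c(O)c1`. It has 3-cyanophenyl in place of 4-cyanophenyl on an aromatic nitrogen of the five-membered aromatic ring: 3-cyanophenyl in place of 4-cyanophenyl on an aromatic nitrogen. The atoms stay the same, and only the way they are joined changes.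

For the measured compounds named here, only one measured step exists, a number 20.3 percentage points lower from compound 1 to compound 2 (beyond the scatter). It is a modest step beyond the scatter, but it concerns hydroxymethyl in place of hydrogen on a saturated chain carbon, in compounds that lack the triazole-bearing part altogether. Going by the values given here, it therefore says little about this change, and no measured pair moves a nitrile around an aromatic ring. With no evidence for a shift in either direction, no change beyond the scatter is expected in this assay. The expected step is small, a number 2.7 percentage points lower from compound 3 to compound 4 (within the scatter). For compound 4 the estimated value is 33%, with an expected range from 18% to 48%.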

Compound 4, percent growth inhibition at one concentration: 31.9%
Compound 4: the middle estimate sits 1.1 percentage points above what was measured; the measured number falls inside the stated range.
By their numbers in this assay, from the lowest: compound 2; then compounds 4, 3 and 1 (each within the scatter of the next).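

In this assay, for the compounds shown here, moving from 4-cyanophenyl to 3-cyanophenyl on the aromatic nitrogen gives a number 3.8 percentage points lower from compound 3 to compound 4 (within the scatter), the first measured pair in which a nitrile changes place on a phenyl ring. With the atoms unchanged and only their joining altered, this assay does not tell the two arrangements apart, so for this pair the growth inhibition reading tolerates the change at this position of the phenyl ring. No supporting measurement shown here accounts for this result or ties it to any property of either group.

This single pair does not show whether the nitrile itself contributes to the inhibition, which a plain phenyl, or a phenyl bearing a carboxylic acid, an amine or a methoxy group in its place, would begin to address. It also leaves open whether the two arrangements would stay this close at other concentrations or in other cell lines, since one reading at one concentration says nothing about the shape of a dose-response curve.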